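Replacing 3-nitrophenyl with 4-methylphenyl on the shared core

The source may hold more compounds than are shown below. What is called first, only, known or untested is meant among the compounds shown, and "the series" means these compounds.

Compound 1 `CC1(C)Cc2c(ccc(C(=O)/C=C/c3cn(-c4ccccc4)nc3-c3cccc([N+](=O)[O-])c3)c2OCc2ccccc2)O1` was examined in a functional assay on HT-29 cells (Homo sapiens) for antiproliferative activity, read by MTT assay, with a stated time of 48 h; on this read-out higher numbers stand for weaker inhibition and lower numbers for stronger inhibition. In this assay compound 1 gives > 100000 nM, a limit of the assay rather than a number. Compound 2 `CC1(C)Cc2c(ccc(C(=O)/C=C/c3ccc(Cl)cc3)c2OCc2ccccc2)O1` gives in this assay > 100000 nM, likewise a limit. Compound 1 thus sits at the limit of > 100000 nM in this assay, at which 2 of the 2 values shown sit. Compound 3 `Cc1ccc(-c2nn(-c3ccccc3)cc2/C=C/C(=O)c2ccc3c(c2OCc2ccccc2)CC(C)(C)O3)cc1` differs from compound 1 in one place: 4-methylphenyl in place of 3-nitrophenyl on an aromatic carbon. For the measured compounds named here, no measured step between these compounds exists. The step of a number no higher from compound 1 to compound 3 (the limit leaves the size open) is expected to stay within the usual scatter. In this assay compound 3 is expected to give about 100000 nM, most likely between 30000 nM and 300000 nM.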

Compound 3, half-maximal inhibitory concentration: > 100000 nM
Compound 3 was reported as a limit (the forecaster's own chance of this, stated with the estimate: 75%); the middle value sits exactly at the limit.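

In this assay compound 3 gives > 100000 nM, a limit of the assay. For the compounds shown here, compound 1 also gives a limit, so no step from compound 1 to compound 3 can be read. The compounds shown leave open how any change on the shared core alters inhibition, as every value is a limit: the limit of > 100000 nM in this assay, at which 3 of the 3 values shown sit.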